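The source may hold more compounds than are shown below. What is called first, only, known or untested is meant among the compounds shown, and "the series" means these compounds.

In a functional assay on MCF7 cells (Homo sapiens) for antiproliferative activity, read by sulforhodamine B assay, with a stated time of 48 h (a higher number here means a weaker inhibitor, a lower number a stronger inhibitor), compound 3 (`O=C1NCCN1c1ccc(S(=O)(=O)Nc2ccc(I)cc2)cc1`) gives 600 nM. Compound 1 (`CCc1ccccc1NS(=O)(=O)c1ccc(N2CCNC2=O)cc1`) gives 350 nM, and the step between them is a 1.7-fold higher number from compound 1 to compound 3 (0.23 log units; within the scatter). Compound 2 (`Cc1cccc(NS(=O)(=O)c2ccc(N3CCNC3=O)cc2)c1`) gives 190 nM, and the step to compound 3 is a 3.2-fold higher number from compound 2 to compound 3 (0.50 log units; beyond the scatter), so compound 3 stands apart only from compound 2.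

Next in the series is compound 4 (`CCc1ccc(NS(=O)(=O)c2ccc(N3CCNC3=O)cc2)cc1`), with ethyl in place of iodo on an aromatic carbon, para to a large group: ethyl in place of iodo on an aromatic carbon. The 4-iodophenyl thus becomes 4-ethylphenyl.

Among the measured compounds shown here, no measured step makes this exact exchange, so the evidence is indirect. The three measured steps all change the aryl group on the sulfonamide nitrogen, and the remaining one is a 1.8-fold lower number from compound 1 to compound 2 (0.27 log units; within the scatter). Compound 1, which also carries an ethyl group, gives 350 nM. A small move to a lower number is therefore expected in this assay, probably not beyond the scatter. The estimate means a 1.9-fold lower number from compound 3 to compound 4 (0.27 log units; within the scatter), an expected step. Compound 4 is estimated at 320 nM, with an expected range of 130 nM to 700 nM.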

Compound 4, half-maximal inhibitory concentration: 810 nM
For compound 4 the middle estimate is 2.5-fold (0.40 log units) below the measured one; measured number above the stated range.
By their numbers in this assay, from the lowest: compounds 2, 1, 3 and 4 (each within the scatter of the next, the first and the last beyond it).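

In this assay, ethyl in place of iodo on an aromatic carbon, para to a large group, stays within the scatter (a 1.4-fold higher number from compound 3 to compound 4 (0.13 log units; within the scatter)), so these two groups are not told apart at this position. Compound 4 stands apart from both other aryl variants (a 2.3-fold higher number from compound 1 to compound 4 (0.36 log units; beyond the scatter); a 4.3-fold higher number from compound 2 to compound 4 (0.63 log units; beyond the scatter)), whereas compound 3 stood apart only from compound 2. No measurement on hand accounts for these differences.

Compounds 1, 2 and 4 differ in both the group and where it sits on the aryl ring, so a 3-ethylphenyl compound would be needed to separate the two changes. Also open, as far as these compounds go, is how a 4-aminophenyl, a 4-carboxyphenyl or a longer chain than ethyl on the same ring would compare with 4-ethylphenyl.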